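The source may report more compounds than this note shows. Statements on the series, on what has been measured and on what is new or still open speak of the compounds shown alone.

Three members of the series have been run in an ADME assay on HepG2 cells (Homo sapiens) for cytotoxicity, read by CellTiter-Glo and ATP content, with a stated time of 72 h; on this read-out lower numbers stand for an effect already at smaller amounts and higher numbers for an effect only at larger amounts of compound. Compound 1 `Cc1ccc(N2CCN(C(=O)C3CCN(C(=O)c4ccc(S(C)(=O)=O)c([N+](=O)[O-])c4)CC3)CC2)cc1` returns no number but a limit of the assay, > 27000 nM. Compound 2 `CC1CCN(C(=O)CCNC(=O)c2ccc(S(C)(=O)=O)c([N+](=O)[O-])c2)CC1` likewise returns only a limit, > 27000 nM. Compound 3 `CN(Cc1ccccc1F)C(=O)C1CCN(C(=O)c2ccc(S(C)(=O)=O)c([N+](=O)[O-])c2)CC1` also gives a limit rather than a number, > 27000 nM. Among the compounds with values here, all three results sit at the same point, (the limit of > 27000 nM in this assay, at which 3 of the 3 values shown sit), so no step between measured compounds can be drawn from them. Compound 2 thus stands where compound 1 and compound 3 stand: at the limit, without a number of its own, and nothing in the set separates it from the other two.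

Compound 4 `CS(=O)(=O)c1ccc(C(=O)NCCC(=O)N2CCCCC2)cc1[N+](=O)[O-]` is not yet measured in this assay. It differs from compound 2 by hydrogen in place of methyl on a saturated ring carbon. Within the data shown here, no measured pair carries this change, so its effect is unknown from the data. With compound 2 at the limit, the step is expected to be none beyond the scatter, a step that the limit leaves unreadable from compound 2 to compound 4. Compound 4 is accordingly estimated at 30000 nM in this assay, with a range from 15000 nM to 60000 nM, and is most likely to return again only a limit.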

Compound 4, half-maximal effective concentration: > 27000 nM
Compound 4: a limit, no number; the forecaster's own chance of this, stated with the estimate: 90%; the middle value is on the limit's open side.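

Compound 4, like compound 2, returns only a limit and no number, so no step can be read between them: the limit of > 27000 nM in this assay, at which 4 of the 4 values shown sit.

The compounds shown leave open whether hydrogen in place of methyl changes the read-out, and where any of these compounds would give an actual half-maximal effective concentration.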